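Triazolothiadiazine series: aryl swap at the imine carbon

The source may report more compounds than this note shows. Statements on the series, on what has been measured and on what is new or still open speak of the compounds shown alone.

Measured so far:
compound 1, `CC(c1ccc(-c2ccccc2)c(F)c1)c1nnc2n1N=C(c1ccc(Cl)cc1Cl)CS2`, 8600 nM
compound 2, `CC(c1ccc(-c2ccccc2)c(F)c1)c1n[nH]c(=S)n1N`, 21400 nM
compound 3, `Cc1ccc(C2=Nn3c(nnc3C(C)c3ccc(CC(C)C)cc3)SC2)cc1`, 7300 nM

In a functional assay on HepG2 cells (Homo sapiens) for inhibition, read by sulforhodamine B assay, with a stated time of 72 h (a lower number here means a stronger inhibitor, a higher number a weaker inhibitor), compound 1 gives 8600 nM and sits second highest of the three numbers. Compound 3 is within the scatter of it, so no order between compound 1 and compound 3 can be read; compound 2 lies beyond the scatter with the highest number, and its structure lacks the fused ring system of the other two.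

Compound 4, `CC(c1ccc(-c2ccccc2)c(F)c1)c1nnc2n1N=C(c1ccc(F)cc1)CS2`, has not yet been run in this assay. Relative to compound 1 the change is:
4-fluorophenyl in place of 2,4-dichlorophenyl on a carbon with a double bond to nitrogen
Nothing measured here isolates this aryl change; compound 3 carries yet another aryl group, but with a different substituent on the shared core, so its value only shows that a single-substituent phenyl at this position is compatible with a number in the same region as compound 1. The step from compound 1 to compound 4 is therefore expected to stay small, most likely a modest rise or none beyond the scatter: a 1.4-fold higher number from compound 1 to compound 4 (0.14 log units; within the scatter). Compound 4 is estimated at 12000 nM, with a range of 5000 nM to 30000 nM.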

Compound 4, half-maximal inhibitory concentration: 5100 nM
The estimate for compound 4 lay 2.4-fold (0.37 log units) above the measured number; the range from low to high includes it.
By their numbers in this assay, from the lowest: compounds 4, 3 and 1 (each within the scatter of the next); then compound 2.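

The exchange of 2,4-dichlorophenyl for 4-fluorophenyl on the carbon with a double bond to nitrogen gives, in this assay, a 1.7-fold lower number from compound 1 to compound 4 (0.23 log units; within the scatter), so compound 1 and compound 4 cannot be ordered. Going by these compounds alone, this is the first direct reading at this position: with the rest of the structure held constant, neither chlorine is needed for compound 4 to stay in the same range as compound 1. No measured information bears on the reason for this result.

It remains open whether any replacement at this position moves the number beyond the scatter, as the one pair shown stays within it. Also open, as far as these compounds go, is how this carbon responds to a phenyl bearing an amine or a carboxylic acid, or to a longer alkyl chain in place of the phenyl.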